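The compounds below may be only part of what the source reports. "The series", "measured", "known", "first", "only" and "open" are said of these compounds alone.

Measured compounds:
Compound 1 `CC(C)(C)OC(=O)N1CCN(C(=O)Cn2cc(CN3C(=O)C(=O)c4c(Cl)ccc(Cl)c43)nn2)CC1`: 22000 nM
Compound 2 `O=C(Cn1cc(CN2C(=O)C(=O)c3c(Cl)ccc(Cl)c32)nn1)NC1CCCCC1`: 17400 nM

In a functional assay on MGC-803 cells (Homo sapiens) for inhibition, read by CCK-8 assay, with a stated time of 72 h (on this read-out lower numbers stand for stronger inhibition and higher numbers for weaker inhibition), compound 1 gives 22000 nM and compound 2 gives 17400 nM. Compound 2 holds the smaller of the two numbers shown; its nearest neighbour is compound 1, and the gap between them lies within the usual scatter, so no ranking of the two follows from these data. Both sit in the same weak region of the read-out.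

Compound 3 `O=C1C(=O)N(Cc2cn(CC(=O)N3CCCC3)nn2)c2c(Cl)ccc(Cl)c21` has not yet been measured. It differs from compound 2 in one place: pyrrolidin-1-yl in place of cyclohexylamino on a carbonyl carbon. Among the compounds with values here, no step between measured compounds is on hand, so the weight of this change cannot be read from any earlier pair; the account rests only on the two values above and on the change itself. The shared core and the chain bearing the carbonyl are untouched, and the two measured amides give closely similar numbers.

The step that this estimate means, a 1.1-fold higher number from compound 2 to compound 3 (0.06 log units; within the scatter), is expected to stay within the scatter, with no clear direction. Compound 3 is therefore estimated at 20000 nM, with a range from 7000 nM to 60000 nM.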

Compound 3, half-maximal inhibitory concentration: 14800 nM
Compound 3: the middle estimate sits 1.4-fold (0.13 log units) above what was measured; the measured number falls inside the stated range.
By their numbers in this assay, from the lowest: compounds 3, 2 and 1 (each within the scatter of the next).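

In this assay, within the data shown here, pyrrolidin-1-yl in place of cyclohexylamino on a carbonyl carbon gives a 1.2-fold lower number from compound 2 to compound 3 (0.07 log units; within the scatter) and so provides the first step at this position that can be read in one place. The change removes the amide hydrogen, the one hydrogen-bond donor counted in the group that leaves, and puts a five-membered ring with one hetero atom where a six-membered ring of carbon only stood, yet this pair shows no difference that the read-out can separate from the scatter. No independent measurement bears on this result.

As far as these compounds go, it remains open whether any group on this carbonyl carbon can move the number beyond the scatter, and a morpholine, an anilino group or an open-chain dimethylamino group would each test this in one place against compound 3. From the compounds shown here alone, it also remains open how much the shared core and the chain bearing the carbonyl contribute to the weak level of the read-out, as both are the same in compound 2 and compound 3.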